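This account rests on a few compounds, and the source may have more. Where it says the series, first, only, none or still open, it means among the compounds named here.

Among the measured compounds shown here, compound 1 `COc1cc(OC)c(OC)cc1/C=C/COC(=O)/C=C/c1cccc(Br)c1` gives 497 umol/kg in a functional assay on the whole organism (strain Kunming) with Mus musculus as the target, with a stated time of 0.5 h (a lower number here means that less compound is needed, a higher number that more compound is needed for the effect), and is the only compound in this small set with an actual number. Compound 2 `COc1cc(OC)c(OC)cc1/C=C/COC(=O)/C=C/c1ccc(OC)c(OC)c1OC` reads > 674 umol/kg in this assay and this is a limit of the assay, not a number. Compound 3 `COc1ccc(/C=C/C(=O)OC/C=C/c2cc(OC)c(OC)cc2OC)cc1` keeps the core of compound 1 and carries 4-methoxyphenyl in place of 3-bromophenyl on a double-bonded chain carbon bound to a double-bonded chain carbon. For the measured compounds named here, no step between measured compounds is available to guide this change, so the expectation rests on compound 1 alone. No shift beyond the usual scatter is expected in this assay and any drift would more likely be towards a higher dose. The estimated 1.1-fold higher number from compound 1 to compound 3 (0.05 log units; within the scatter) stays within that scatter. Compound 3 is expected at 560 umol/kg (estimated range 300 umol/kg to 1000 umol/kg).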

Compound 3, dose for half-maximal effect: > 780 umol/kg
Compound 3: no number, only a limit; the forecaster's own chance of this, stated with the estimate: 35%; at least 1.3-fold (0.14 log units) between middle value and limit.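

Among the compounds shown here, this is the first one-place comparison at this chain carbon: in this assay, putting 4-methoxyphenyl in place of 3-bromophenyl gives an at least 1.5-fold higher number from compound 1 to compound 3 (0.19 log units; that floor lies within the scatter). Compound 3 has no number in this read-out, only a limit, so the change can be stated only as a floor: the limit of > 780 umol/kg in this assay, at which 1 of the 3 values shown sits. Even so, the change gives no sign that 4-methoxyphenyl lowers the dose needed, although that floor lies within the scatter and does not by itself establish a real rise.

Going by these compounds, whether the true gap between these two compounds lies beyond the scatter remains open. On these data alone, how a phenyl ring carrying an amine or a carboxylic acid would read at this place in this assay also remains open.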